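The source may report more compounds than this note shows. Statements on the series, on what has been measured and on what is new or still open speak of the compounds shown alone.

Compound 1 `CC(=O)OC/C1=C/C[C@](C)(CCC=C(C)C)/C=C/[C@@H](OC(=O)C=C(C)C)[C@](C)(OC(C)=O)/C=C/C1=O` gives 3520 nM in a functional assay on SW480 cells (Homo sapiens) for antiproliferative activity, read by MTT assay, with a stated time of 48 h; on this read-out higher numbers stand for weaker inhibition and lower numbers for stronger inhibition. Compound 2 `CC(C)=CCC[C@]1(C)/C=C/[C@@H](OC(=O)C=C(C)C)[C@](C)(O)/C=C/C(=O)/C(C(=O)O)=C\C1` is known in this assay only as a limit of > 10000 nM, not as a number. Its standing among the values shown is therefore described by the limit of > 10000 nM in this assay, at which 1 of the 2 values shown sits, alone, and it lies at the weak end of the two values given. Compound 3 `CSC(=S)OC/C1=C/C[C@](C)(CCC=C(C)C)/C=C/[C@@H](OC(=O)C=C(C)C)[C@](C)(O)/C=C/C1=O` has not yet been measured. It differs from compound 2 by a group of 6 heavy atoms (3 carbon, 1 oxygen, 2 sulfur; no ring) in place of a group of 3 heavy atoms (1 carbon, 2 oxygen; no ring), on a double-bonded ring carbon. For the measured compounds named here, no step between measured compounds exists to set the scale of this change, so the expectation rests on the two values shown. Compound 2 sits at a limit, so the expected step from compound 2 to compound 3 is an at least 2.5-fold lower number from compound 2 to compound 3 (0.39 log units; beyond the scatter), toward stronger inhibition in this assay, and may be larger. Compound 3 is estimated at 4000 nM in this assay, with a range from 1500 nM to 15000 nM.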

Compound 3, half-maximal inhibitory concentration: 390 nM
The estimate for compound 3 lay 10-fold (1.01 log units) above the measured number, outside the stated range (below it).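

In this assay, this position on a double-bonded ring carbon proves sensitive to what it carries: putting the group of 6 heavy atoms (3 carbon, 1 oxygen, 2 sulfur) in place of the carboxy group gives an at least 25-fold lower number from compound 2 to compound 3 (1.40 log units; beyond the scatter). This step lies beyond the scatter, and with one end fixed only by a limit, its true size may be larger still. Compound 2 is known only as a limit, not as a number: the limit of > 10000 nM in this assay, at which 1 of the 3 values shown sits.

The compounds shown leave open which part of the entering group goes with the stronger inhibition, and whether an amine, a methyl ester or a longer chain on the same ring carbon would give a similar number. The reason for the step also stays open.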